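A few compounds are considered here, and "the series" means these few. Any claim that something is new, unique, unknown or untested is made for them only; others in the source may bear on it.

Measured compounds:
Compound 1 `Cc1ccsc1CN(C(=O)Nc1ccccc1)n1cnnc1`: in a functional assay on DU-145 cells (Homo sapiens) for cytotoxicity, read by MTT assay, with a stated time of 48 h (a higher number here means a weaker inhibitor, a lower number a stronger inhibitor), compound 1 gives > 50000 nM, which is a limit of the assay rather than a number.
Compound 2 `O=C(Nc1ccccc1)N(Cc1ccccn1)n1cnnc1`: in this assay compound 2 gives 20200 nM.

Compound 2 thus holds the only actual number shown; the other value is a limit. Compound 3 `N#Cc1ccc(CN(C(=O)Nc2ccccc2)n2cnnc2)cc1` has not yet been measured. It differs from compound 2 by 4-cyanophenyl in place of pyridin-2-yl on a saturated chain carbon bound to an amide-type nitrogen. Going by the values given here, one measured step touches the same place: an at least 2.4-fold lower number from compound 1 to compound 2 (0.39 log units; beyond the scatter). That step shows that swapping the aromatic group on this carbon can move the result, though its true size is not known because one end sits at the limit of > 50000 nM in this assay, at which 1 of the 2 values shown sits. Compound 3 exchanges one six-membered ring for another carrying a nitrile, a change of a kind similar to the measured one but with no sign pointing either way, so a step of about a 1.0-fold lower number from compound 2 to compound 3 (0.00 log units; within the scatter) is expected, that is, no shift beyond the scatter. Compound 3 is therefore estimated at 20000 nM, with a range from 8000 nM to 50000 nM.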

Compound 3, half-maximal inhibitory concentration: > 50000 nM
Compound 3 ended at the assay's limit; the forecaster's own chance of this, stated with the estimate: 25%; at least 2.5-fold (0.39 log units) between middle value and limit.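

In this assay, swapping one six-membered aromatic ring for another on this saturated chain carbon bound to an amide-type nitrogen is enough to change the result: putting 4-cyanophenyl in place of pyridin-2-yl gives an at least 2.4-fold higher number from compound 2 to compound 3 (0.39 log units; beyond the scatter). Compound 2 therefore remains the only one of the three with an actual number, and neither the thiophene-bearing group of compound 1 nor the 4-cyanophenyl group of compound 3 matches it. The full size of the new step is unknown because its upper end is a limit of the assay, and the step between compound 1 and compound 3 cannot be read at all, as both of its ends are limits: the limit of > 50000 nM in this assay, at which 2 of the 3 values shown sit.

The compounds shown do not separate the role of the ring nitrogen in pyridin-2-yl from that of the nitrile in 4-cyanophenyl, as the two groups differ in both features. They also leave open how a plain phenyl group on this carbon, or a longer chain leading to the pyridine ring, would compare with compound 2.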